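The compounds below may be only part of what the source reports. "The series", "measured", "known", "first", "only" and "open" are said of these compounds alone.

Of the compounds shown here, three built on one shared core have been tested in a functional assay on SMMC-7721 cells (Homo sapiens) for antiproliferative activity, read by MTT assay, with a stated time of 72 h; on this read-out higher numbers stand for weaker inhibition and lower numbers for stronger inhibition. Compound 1 `C#CCSc1nc(Sc2nnnn2CCN(C)C)c(C#N)c(-c2cccc(Cl)c2)n1` gives 8640 nM. Compound 3 `C#CCSc1nc(Sc2nccs2)c(C#N)c(-c2ccc(C)cc2)n1` gives 2450 nM. Compound 2 `C#CCSc1nc(Sc2nc3ccccc3s2)c(C#N)c(-c2cc(OC)c(OC)c(OC)c2)n1` reaches only a limit of the assay, reported as > 20000 nM, so no exact number is known for it. Compound 2 therefore sits at the weak end of what has been measured, at the limit of > 20000 nM in this assay, at which 1 of the 3 values shown sits.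

Compound 4 `C#CCSc1nc(Sc2nc[nH]n2)c(C#N)c(-c2cc(OC)c(OC)c(OC)c2)n1` differs from compound 2 in a single place: 1H-1,2,4-triazol-3-yl in place of 1,3-benzothiazol-2-yl on a sulfur. Among the compounds with values here, no two measured compounds differ from each other in exactly this way, so the size of this step cannot be read from the data. Compound 1 and compound 3 carry other groups in that position and do land at measured numbers, which leaves the direction of the step open. For compound 4 in this assay a step of an at least 1.3-fold lower number from compound 2 to compound 4 (0.12 log units; that floor lies within the scatter) is expected, modest in size. The estimate for compound 4 is 15000 nM, expected to fall between 4000 nM and 40000 nM.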

Compound 4, half-maximal inhibitory concentration: > 20000 nM
Compound 4: only a limit was reported (the forecaster's own chance of this, stated with the estimate: 45%); middle value at least 1.3-fold (0.12 log units) away from the limit.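

In this assay, within the data shown here, compound 2 and compound 4 both stop at a limit of the assay, so no step between them can be read: the limit of > 20000 nM in this assay, at which 2 of the 4 values shown sit. The compounds shown leave open how far either compound lies past that limit, and so whether 1H-1,2,4-triazol-3-yl in place of 1,3-benzothiazol-2-yl changes activity at all.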